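The source may hold more compounds than are shown below. What is called first, only, known or untested is meant among the compounds shown, and "the series" means these compounds.

In an ADME assay on TERT-RPE1 cells (Homo sapiens) for cytotoxicity, read by MTT assay, with a stated time of 72 h (on this read-out lower numbers stand for stronger inhibition and higher numbers for weaker inhibition), compound 3, whose structure is `COc1ccc(/C=C2\S/C(=N\c3ccc(Cl)cc3)N(C)C2=O)cc1`, reaches only the limit of the assay, > 100000 nM, so its true number is not known; this is the limit described in the limit of > 100000 nM in this assay, at which 1 of the 3 values shown sits. Two related compounds have proper numbers. Compound 1, with the structure `COc1ccc(/C=C2\S/C(=N\c3ccc(C(C)(C)C)cc3)N(C)C2=O)cc1`, gives 46700 nM in this assay, and compound 2, with the structure `COc1ccc(/C=C2/CN(C)/C(=N/c3ccc(Cl)cc3)S2)cc1`, gives 39600 nM in this assay. Within the data shown here, the one step that can be read is an at least 2.1-fold higher number from compound 1 to compound 3 (0.33 log units; beyond the scatter), which means compound 3 is at least a little weaker than compound 1 at harming these cells.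

Compound 4, with the structure `COc1ccc(/C=C2\S/C(=N\c3c(C)cccc3C)N(C)C2=O)cc1`, differs from compound 3 in one place: 2,6-dimethylphenyl in place of 4-chlorophenyl on a double-bonded nitrogen. Among the measured compounds shown here, no measured step covers this particular exchange, and the only step measured, from compound 1 to compound 3, was at least modest. With all three measured compounds weak in this assay, compound 4 is expected to stay weak as well, with a step of an at least 1.1-fold lower number from compound 3 to compound 4 (0.04 log units; that floor lies within the scatter) that is not expected to exceed the scatter. Compound 4 is therefore estimated at 90000 nM, in a range from 40000 nM to 200000 nM, and a limit rather than a number is considered likely.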

Compound 4, half-maximal inhibitory concentration: > 100000 nM
Compound 4: a limit, no number; the forecaster's own chance of this, stated with the estimate: 55%; middle value at least 1.1-fold (0.04 log units) away from the limit.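

Compound 4 gives > 100000 nM in this assay and that is a limit, not a number. Among these compounds, compound 3 also stands at a limit, so no step from compound 3 to compound 4 can be read: the limit of > 100000 nM in this assay, at which 2 of the 4 values shown sit. Left open is how far apart the true numbers of compound 3 and compound 4 lie, and in which direction.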